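Swapping trifluoromethyl for methoxy: what to expect

The source may report more compounds than this note shows. Statements on the series, on what has been measured and on what is new or still open speak of the compounds shown alone.

compound 1 `CC(=O)Oc1ccc(/C=C/C(=O)OC2CCCCC2)cc1OC(C)=O` gives 200 nM
compound 2 `Cc1ccc(CNC(=O)/C=C/c2ccc(O)c(O)c2)cc1` gives 3700 nM
compound 3 `O=C(/C=C/c1ccc(O)c(O)c1)NCc1ccc(C(F)(F)F)cc1` gives 1600 nM

In a functional assay on B16 cells (Mus musculus) for inhibition (on this read-out higher numbers stand for weaker inhibition and lower numbers for stronger inhibition), compound 3 holds the middle place of the three numbers, lower than compound 2 and higher than compound 1. Compound 4 `COc1ccc(CNC(=O)/C=C/c2ccc(O)c(O)c2)cc1` carries methoxy in place of trifluoromethyl on an aromatic carbon, para to a large group (methoxy in place of trifluoromethyl on an aromatic carbon). Going by the values given here, one measured step bears on this change: trifluoromethyl in place of methyl gave a 2.3-fold lower number from compound 2 to compound 3 (0.36 log units; beyond the scatter) and counts as modest. Among the compounds with values here, no methoxy compound has been measured yet, so the guide is thin. Losing trifluoromethyl may give back part of that modest gain, so a small move toward a higher number seems likely. The expected step is a 1.6-fold higher number from compound 3 to compound 4 (0.19 log units; within the scatter) and may well stay within the scatter. For compound 4 the estimated value is 2500 nM (expected range 1000 nM to 6000 nM).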

Compound 4, half-maximal inhibitory concentration: 6200 nM
Estimate against measurement, compound 4: 2.5-fold (0.39 log units) below; the whole stated range lies below it.
By their numbers in this assay, from the lowest: compound 1; then compound 3; then compounds 2 and 4 (each within the scatter of the next).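

In this assay, methoxy in place of trifluoromethyl gives a 3.9-fold higher number from compound 3 to compound 4 (0.59 log units; beyond the scatter), so the gain seen with trifluoromethyl does not carry over to this oxygen-linked group. Methoxy in place of methyl gives a 1.7-fold higher number from compound 2 to compound 4 (0.22 log units; within the scatter), so these two groups cannot be told apart here, and of the three groups at this place only trifluoromethyl stands apart. Nothing measured here explains why trifluoromethyl differs from the other two. As far as these compounds go, whether a chlorine atom, a nitrile or an amine at this place would match trifluoromethyl remains open. Also open, from the compounds shown here alone, is whether trifluoromethyl would stand apart in the same way on another core.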